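A methylsulfanyl oxazole in place of a methyl oxazole

The source may hold more compounds than are shown below. What is called first, only, known or untested is meant among the compounds shown, and "the series" means these compounds.

The shared core of this small set is a ketone linking a substituted oxazole to a saturated chain ending in a benzene ring, tested in an assay on HEK-293T cells for inhibition of diacylglycerol lipase-alpha (Homo sapiens), read by colorimetric assay; a higher number here means a weaker inhibitor, a lower number a stronger inhibitor. Compound 1 `CC(=O)c1coc(C(=O)CCCCCCc2ccccc2)n1` carries an acetyl on its oxazole and in this assay gives 123 nM. Compound 2 `Cc1coc(C(=O)CCCCCCc2ccccc2)n1` carries a methyl instead, and in this assay compound 2 is reported only as a limit of the assay, > 10000 nM. Compound 3 `CNC(=O)c1coc(C(=O)CCCCCCc2ccccc2)n1` carries a methylcarbamoyl, and in this assay compound 3 likewise is reported only as a limit, > 10000 nM. The step of an at least 81-fold higher number from compound 1 to compound 2 (1.91 log units; beyond the scatter) and the step of an at least 81-fold higher number from compound 1 to compound 3 (1.91 log units; beyond the scatter) both show that removing the acetyl costs a great deal, so that compound 2 stands at the weak end of what is shown, where the limit of > 10000 nM in this assay, at which 2 of the 3 values shown sit, holds two of the three values.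

Compound 4 `CSc1cnc(C(=O)CCCCCCc2ccccc2)o1` differs from compound 2 by the change (5-(methylsulfanyl)-1,3-oxazol-2-yl in place of 4-methyl-1,3-oxazol-2-yl on a carbonyl carbon). Among the compounds with values here, no measured step touches a methylsulfanyl group, and since compound 2 is a limit, the two acetyl-loss steps only say that a substituent unlike acetyl has not restored potency. A step such as an at least 1.2-fold lower number from compound 2 to compound 4 (0.09 log units; that floor lies within the scatter) is therefore expected, with no reading of direction possible beyond the scatter. Compound 4 is estimated at 8000 nM, within 1000 nM to 40000 nM.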

Compound 4, half-maximal inhibitory concentration: > 10000 nM
Compound 4: a limit, no number (the forecaster's own chance of this, stated with the estimate: 55%); at least 1.2-fold (0.09 log units) between middle value and limit.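

In this assay compound 4 is reported only as a limit, > 10000 nM. Compound 2 is a limit as well, so no step can be read between compound 2 and compound 4. The compounds shown leave open whether the 5-(methylsulfanyl)-1,3-oxazol-2-yl group and the 4-methyl-1,3-oxazol-2-yl group differ at all in this inhibition.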